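Fluoro for methyl on two isomeric cores against topoisomerase 1

The source may report more compounds than this note shows. Statements on the series, on what has been measured and on what is new or still open speak of the compounds shown alone.

The study compares four compounds that share one aryl substituent pattern but sit on two different cores. Compound 1 `Cc1ccc2c(=O)[nH]c(-c3ccccc3C)nc2c1` and compound 2 `Cc1ccc2nc(-c3ccccc3C)[nH]c(=O)c2c1` are built from the same atoms joined differently; the difference between the two cores is not broken down here. In an assay on isolated protein for inhibition of DNA topoisomerase 1 (Homo sapiens), with a stated time of 30 min, tested at 100 uM (on this read-out higher numbers stand for a stronger effect at the one concentration tested and lower numbers for a weaker effect), compound 1 gives 100%, whereas compound 2 gives 0%, the lowest of the three measured numbers and far beyond the scatter from either of the others.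

Compound 3 `Cc1ccc2c(=O)[nH]c(-c3ccccc3F)nc2c1` differs from compound 1 by a single change, (fluoro in place of methyl on an aromatic carbon). In this assay compound 3 gives 81.2%. This change produced a number 18.8 percentage points lower from compound 1 to compound 3 (beyond the scatter), so the core of compound 1 tolerates the swap with only a modest loss.

Compound 4 `Cc1ccc2nc(-c3ccccc3F)[nH]c(=O)c2c1` is the unmeasured partner: it stands to compound 2 as compound 3 stands to compound 1, with the change (fluoro in place of methyl on an aromatic carbon), at the very same place on the aryl ring. Among the compounds with values here, since compound 2 gives 0%, the lowest of the measured numbers, and the one measured instance of this change lowered the number rather than raising it, there is little room for compound 4 to move. The expected step for compound 4 is therefore a number 5 percentage points higher from compound 2 to compound 4 (within the scatter), essentially flat beside the earlier step, which rests on the value of compound 2, 0%, and the direction of the step from compound 1 to compound 3. Compound 4 is estimated at 5%, with a likely range from 0% to 25%.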

Compound 4, a percentage reported as inhibition, at one concentration (the size of the read-out at that concentration, not a potency): 67.9%
For compound 4 the middle estimate is 62.9 percentage points below the measured one, and the stated range ends below it.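

In this assay, the swap of fluoro in place of methyl on an aromatic carbon did not carry over from one core to the other. On the core of compound 2 it produced a number 67.9 percentage points higher from compound 2 to compound 4 (beyond the scatter), and this step differs from the earlier one in both direction and size: the same change on two cores in this assay, a number 18.8 percentage points lower (beyond the scatter) from compound 1 to compound 3 and a number 67.9 percentage points higher (beyond the scatter) from compound 2 to compound 4, 86.7 percentage points apart, beyond the scatter of two such steps. With one matched pair on each core, this shows only that the result of the change depended on the core in these four compounds; it does not show what in the two cores lies behind the difference, whether the same divergence would appear for another replacement, or how potency would compare, since each number comes from a single concentration.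

The compounds shown leave open how a chloro group, a methoxy group or a plain hydrogen at the same place on the aryl ring would read on each core, and so whether the methyl of compound 2 is a special case or fluoro in compound 4 is. They also leave open whether an amine or a carboxylic acid on that ring would follow the pattern of either core, and whether replacing the methyl on the fused ring would change the outcome.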